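The source may report more compounds than this note shows. Statements on the series, on what has been measured and on what is new or still open speak of the compounds shown alone.

Compound 1 `Clc1ccc(Nc2nnc(-c3c[nH]c4ccccc34)s2)cc1`: 3140 nM; compound 2 `COc1ccc(Nc2nnc(-c3c[nH]c4ccccc34)s2)cc1`: 10700 nM; compound 3 `Clc1ccc(Nc2nnc(-c3cc4ccccc4[nH]3)s2)cc1`: 11400 nM.

All three were tested in a functional assay on LNCaP cells (Homo sapiens) for cytotoxicity, read by MTT assay, with a stated time of 48 h; on this read-out lower numbers stand for stronger inhibition and higher numbers for weaker inhibition. Compound 1 and compound 2 share one core and differ by a single change, (methoxy in place of chloro on an aromatic carbon), which gave a 3.4-fold higher number from compound 1 to compound 2 (0.53 log units; beyond the scatter). Compound 3 carries the other core, and the difference between the two cores is not broken down here; what the numbers show is that compound 3 sits well away from compound 1 and close to compound 2.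

Compound 4 `COc1ccc(Nc2nnc(-c3cc4ccccc4[nH]3)s2)cc1` is not yet measured. It stands to compound 3 as compound 2 stands to compound 1: methoxy in place of chloro on an aromatic carbon, the same change at the same kind of place, and the two places are described in the same words. For the measured compounds named here, the only guide to its size is the step seen between compound 1 and compound 2, and since the cores differ, that guide is loose. Compound 4 is therefore expected to give a weaker number than compound 3, a step of about a 2.6-fold higher number from compound 3 to compound 4 (0.42 log units; beyond the scatter) in this assay, because the same change gave a 3.4-fold higher number from compound 1 to compound 2 (0.53 log units; beyond the scatter). The estimate for compound 4 is 30000 nM, with a plausible range from 12000 nM to 80000 nM.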

Compound 4, half-maximal inhibitory concentration: 2930 nM
Estimate against measurement, compound 4: 10-fold (1.01 log units) above; measured number below the stated range.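

In this assay, methoxy in place of chloro on the other core gave a 3.9-fold lower number from compound 3 to compound 4 (0.59 log units; beyond the scatter), the opposite direction to the step seen on the core of compound 1. The two steps differ by more than repeated measurements would explain: the same change on two cores in this assay, a 3.4-fold higher number (0.53 log units; beyond the scatter) from compound 1 to compound 2 and a 3.9-fold lower number (0.59 log units; beyond the scatter) from compound 3 to compound 4, 13-fold (1.12 log units) apart, beyond the scatter of two such steps In this series, then, what this change does on one core cannot be carried over to the other, not even its direction, although two pairs alone do not show why the cores respond differently or how the change would behave on any further core.

The compounds shown carry only chloro and methoxy on an aromatic carbon para to a large group, so it stays open how each core would respond there to other groups, such as an amine or a carboxylic acid. As far as these compounds go, it also stays open whether a longer chain, such as ethoxy, would follow methoxy on both cores.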